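Swapping the phenyl substituent on the amine nitrogen

The source may report more compounds than this note shows. Statements on the series, on what has been measured and on what is new or still open speak of the compounds shown alone.

Of the compounds shown here, three sharing one core have been measured in a functional assay on MCF7 cells (Homo sapiens) for inhibition, read by sulforhodamine B assay; on this read-out higher numbers stand for weaker inhibition and lower numbers for stronger inhibition. Compound 1 `O=C1C(NC2CC2)=CC(=O)c2c1nc1n2[C@H]2OC[C@@H](O)[C@H]2OC1` carries a cyclopropyl on its amine nitrogen. In this assay compound 1 gives only a limit, > 16000 nM. Compound 3 `O=C1C(Nc2cccc(F)c2)=CC(=O)c2c1nc1n2[C@H]2OC[C@@H](O)[C@H]2OC1` differs from compound 1 by a 3-fluorophenyl in place of cyclopropyl on an amine nitrogen. In this assay compound 3 also gives only a limit, > 4000 nM. The step that the two limits leave unreadable from compound 1 to compound 3 therefore cannot be sized. Going by the values given here, compound 2 `O=C1C=C(Nc2cccc(Cl)c2)C(=O)c2c1nc1n2[C@H]2OC[C@@H](O)[C@H]2OC1` is the one compound with a number in this assay, 4720 nM, which still stands for weak inhibition. Compound 4 `COc1ccccc1NC1=CC(=O)c2nc3n(c2C1=O)[C@H]1OC[C@@H](O)[C@H]1OC3` has not been measured; it differs from compound 2 by 2-methoxyphenyl in place of 3-chlorophenyl on an amine nitrogen. No measured step exchanges one substituted phenyl for another, so nothing shown bears directly on this change. Because compound 2 sits at 4720 nM and the other phenyl-bearing compound, compound 3, is also a weak inhibitor, weak inhibition is expected again. The step of a 1.7-fold higher number from compound 2 to compound 4 (0.23 log units; within the scatter) is expected to stay within the scatter. Compound 4 is estimated at 8000 nM, between 2500 nM and 30000 nM.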

Compound 4, half-maximal inhibitory concentration: > 4000 nM
Compound 4: only a limit was reported; the forecaster's own chance of this, stated with the estimate: 50%; the middle value is on the limit's open side.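

Compound 4 gives only a limit, so the change from compound 2 to compound 4 cannot be sized and no new step can be read. The compounds shown leave open whether 2-methoxyphenyl in place of 3-chlorophenyl on the amine nitrogen alters inhibition at all.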